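Moving the ring nitrogen in a dimethoxypyridine on the core

A few compounds are considered here, and "the series" means these few. Any claim that something is new, unique, unknown or untested is made for them only; others in the source may bear on it.

Compound 1 `COc1cc(F)c(CN2C(=O)N(c3cc(OC)nc(OC)c3)S(=O)(=O)c3ccccc32)c(F)c1` is a sulfonylurea-type compound that in an assay on HEK293 cells for displacement of a labelled ligand from Orexin receptor type 2 (Homo sapiens), read by scintillation counting, with a stated time of 90 min (a lower number here means a stronger inhibitor, a higher number a weaker inhibitor), gives 0.251 nM. Among the three measured compounds it holds the second highest number: compound 2 `COc1cc(F)c(CN2C(=O)N(c3ccc(OC)c(OC)c3)S(=O)(=O)c3ccccc32)c(Cl)c1` gives 0.1 nM, and compound 3 `COc1cc(N2C(=O)N(Cc3c(F)cc(F)cc3F)c3ccccc3S2(=O)=O)cc(OC)n1` gives 1.26 nM. For the measured compounds named here, the one single-point step, a 5.0-fold higher number from compound 1 to compound 3 (0.70 log units; beyond the scatter), concerns the benzyl group and so does not bear on the change studied here. Compound 4 `COc1cc(F)c(CN2C(=O)N(c3cnc(OC)c(OC)c3)S(=O)(=O)c3ccccc32)c(F)c1` differs from compound 1 by 5,6-dimethoxypyridin-3-yl in place of 2,6-dimethoxypyridin-4-yl on an amide-type nitrogen in a ring. Going by the values given here, no measured step isolates this change. Compound 2 carries a dimethoxyphenyl group with a similar arrangement of its methoxy groups together with a different benzyl group, and its number is lower than that of compound 1, but two changes are mixed there, so nothing can be drawn from it alone. The expectation for compound 4 is therefore a number close to compound 1, with a 1.2-fold higher number from compound 1 to compound 4 (0.08 log units; within the scatter) likely within the scatter. Compound 4 is estimated at 0.3 nM, with a range from 0.08 nM to 1.2 nM.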

Compound 4, inhibition constant: 0.398 nM
Estimate against measurement, compound 4: 1.3-fold (0.12 log units) below; measured number inside the range.
By their numbers in this assay, from the lowest: compound 2; then compounds 1 and 4 (each within the scatter of the next); then compound 3.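

In this assay, for the compounds shown here, putting 5,6-dimethoxypyridin-3-yl in place of 2,6-dimethoxypyridin-4-yl on the amide-type nitrogen gives a 1.6-fold higher number from compound 1 to compound 4 (0.20 log units; within the scatter), and this is the first step here that changes this group alone while the benzyl group stays the same. The two groups have the same atoms joined differently, so for this pair, rearranging the ring nitrogen and the methoxy groups at this position leaves no difference that can be told from ordinary repeat variation. Nothing available here offers an explanation for this result.

Both groups are dimethoxypyridines, so the compounds shown leave open how this position would respond to something of a different kind, such as an amine, a carboxylic acid or a longer alkoxy chain. They also cannot separate the contribution of the dimethoxyphenyl group in compound 2 from that of its different benzyl group.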